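A Longer Side Group and Half-Life

The compounds below may be only part of what the source reports. "The series", "measured", "known", "first", "only" and "open" are said of these compounds alone.

- Compound 1 `CC(C)C(Cc1nnc[nH]1)c1ccc(-c2ccc3cccc(F)c3c2)[nH]c1=O`: < 0.0667 h
- Compound 2 `CC(C)C(c1nnc[nH]1)c1ccc(-c2ccc3cccc(F)c3c2)[nH]c1=O`: 0.213 h

Going by the values given here, in an ADME assay on microsomes from liver (Mus musculus) for metabolic stability (a lower number here means that the compound disappears faster, a higher number that the compound lasts longer), compound 2 gives 0.213 h, the only actual number so far. Compound 1 reads < 0.0667 h, which is a limit of the assay and not a number.

Compound 3 `CC(C)C(Cc1noc(=O)[nH]1)c1ccc(-c2ccc3cccc(F)c3c2)[nH]c1=O` differs from compound 2 by a group of 7 heavy atoms (3 carbon, 2 nitrogen, 2 oxygen; one five-membered aromatic ring with 3 hetero atoms) in place of a group of 5 heavy atoms (2 carbon, 3 nitrogen; one five-membered aromatic ring with 3 hetero atoms), on a saturated chain carbon bound to an aromatic carbon and a saturated chain carbon. Among the compounds with values here, one measured step bears on this change: an at least 3.1-fold higher number from compound 1 to compound 2 (0.50 log units; beyond the scatter), which lies beyond the scatter and is itself bounded by that limit. There, 4H-1,2,4-triazol-3-yl replaced (4H-1,2,4-triazol-3-yl)methyl. On this carbon, compound 3 looks more like compound 1 than like compound 2, so a step back towards a lower number is expected. The expected change in this assay is a 2.4-fold lower number from compound 2 to compound 3 (0.37 log units; beyond the scatter). For compound 3 the estimated value is 0.09 h, with an expected range of 0.04 h to 0.2 h.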

Compound 3, half-life: 2.78 h
Beside the measured number, compound 3's estimate is 31-fold (1.49 log units) below it; the measured number lies above the stated range.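

In this assay, the longer side group does not by itself bring a short half-life at this saturated chain carbon: the change gives a 13-fold higher number from compound 2 to compound 3 (1.12 log units; beyond the scatter). With the chain of compound 1 kept, putting the oxygen-bearing five-membered ring in place of the 4H-1,2,4-triazol-3-yl ring gives an at least 41-fold higher number from compound 1 to compound 3 (1.61 log units; beyond the scatter), so at this length the ring makes a large difference. Compound 1 reads as a limit and not a number, so the size of that step is bounded on one side only: the limit of < 0.0667 h in this assay, at which 1 of the 3 values shown sits.

The compounds shown leave open how the oxygen-bearing ring would read if attached directly to the chain carbon, as the 4H-1,2,4-triazol-3-yl ring is in compound 2. They also leave open how a carboxylic acid or an amine would read at this place in this assay.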